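Replacing 4-fluoro-3-methylphenyl with 3,4-dihydroxyphenyl

The source may hold more compounds than are shown below. What is called first, only, known or untested is meant among the compounds shown, and "the series" means these compounds.

Within the data shown here, in a functional assay on DU-145 cells (Homo sapiens) for cytotoxicity (a higher number here means a weaker inhibitor of growth, a lower number a stronger inhibitor of growth), compound 2 `CSc1ccc(C2=C(c3ccc(F)c(C)c3)C(=O)N3CCCC3C2)cc1` gives 500 nM as the lower of the two numbers so far, and compound 1 `COc1ccc(C2=C(c3ccc(SC)cc3)CC3CCCN3C2=O)cc1O` gives 6000 nM as the higher. Compound 3 `CSc1ccc(C2=C(c3ccc(O)c(O)c3)C(=O)N3CCCC3C2)cc1` is unmeasured and carries 3,4-dihydroxyphenyl in place of 4-fluoro-3-methylphenyl on a double-bonded ring carbon with the rest of compound 2 unchanged. Among the measured compounds shown here, the one step bearing on this is the large 12-fold lower number from compound 1 to compound 2 (1.08 log units; beyond the scatter) seen when 4-fluoro-3-methylphenyl replaced 3-hydroxy-4-methoxyphenyl, a group resembling the incoming one. A similarly large rise in this assay is therefore expected, with an 8.0-fold higher number from compound 2 to compound 3 (0.90 log units; beyond the scatter) as the estimated step. For compound 3 the expected value is 4000 nM within an estimated range of 1000 nM to 15000 nM.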

Compound 3, concentration for 50% growth inhibition: 60000 nM
Beside the measured number, compound 3's estimate is 15-fold (1.18 log units) below it; the whole stated range lies below it.
By their numbers in this assay, from the lowest: compound 2; then compound 1; then compound 3.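

In this assay, 3,4-dihydroxyphenyl on this double-bonded ring carbon gives a 120-fold higher number from compound 2 to compound 3 (2.08 log units; beyond the scatter) and so shows that this position is more sensitive than the earlier pair revealed. A single small change also counts here: hydrogen in place of methyl on an oxygen on the aromatic ring gives a 10-fold higher number from compound 1 to compound 3 (1.00 log units; beyond the scatter) and takes the number beyond the scatter. Nothing measured here explains why these numbers move. The compounds shown leave open how an amine or a carboxylic acid on this aromatic ring would behave, and whether 4-hydroxyphenyl, with one hydroxyl only, would resemble compound 2 or compound 3.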